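The compounds below may be only part of what the source reports. "The series", "measured", "known", "first", "only" and "open" are said of these compounds alone.

Measured compounds:
- compound 1 `Cc1ccc(OCC(=O)N(Cc2cccs2)c2ccccn2)cc1`: 200 nM
- compound 2 `O=C(COc1ccc2c(c1)CCC2)N(Cc1cccs1)c1ccn[nH]1`: 0.001 nM
- compound 3 `CCN(Cc1cccs1)C(=O)COc1ccc(C)cc1O`: 8 nM

These three compounds share a core in which an aryloxy-acetamide carries a thiophen-2-ylmethyl group on its amide nitrogen, and they were tested in an assay on HEK293 cells for agonist activity at transient receptor potential cation channel subfamily M member 8 (Homo sapiens), read by fluorescence and calcium flux, with a stated time of 15 min; on this read-out higher numbers stand for an effect only at larger amounts of compound and lower numbers for an effect already at smaller amounts. Compound 1 gives 200 nM in this assay, the highest of the three numbers. Compound 3 comes nearest with 8 nM, while compound 2, with 0.001 nM, is by far the furthest from compound 1.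

Compound 4 `Cc1ccc(OCC(=O)N(CCO)Cc2cccs2)cc1` has not yet been measured. It differs from compound 1 in one place: 2-hydroxyethyl in place of pyridin-2-yl on an amide-type nitrogen. Going by the values given here, no measured pair shows exactly this change. Compound 3 carries an ethyl group on the same nitrogen and gives 8 nM, yet it also differs from compound 1 elsewhere, so it is only a loose guide.

On this basis, a step of a 2.5-fold lower number from compound 1 to compound 4 (0.40 log units; beyond the scatter) toward a lower number is expected, with wide uncertainty. Compound 4 is estimated at 80 nM, within a range of 10 nM to 600 nM.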

Compound 4, half-maximal effective concentration: 900 nM
For compound 4 the middle estimate is 11-fold (1.05 log units) below the measured one; the whole stated range lies below it.
By their numbers in this assay, from the lowest: compound 2; then compound 3; then compound 1; then compound 4.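

Putting 2-hydroxyethyl in place of pyridin-2-yl on the amide-type nitrogen, with the rest of the molecule unchanged, gives a 4.5-fold higher number from compound 1 to compound 4 (0.65 log units; beyond the scatter) in this assay. Going by these compounds alone, this is the first pair that differs only at this nitrogen, and it shows that what sits there matters: here, the open chain with a hydrogen-bond donor needs a larger amount of compound than the aromatic ring. No measurement shown accounts for this step, and the ring leaves as the hydroxyl enters, so the pair cannot single out either part of the change.

As far as these compounds go, it remains open whether phenyl or 2-methoxyethyl on this nitrogen would give a number closer to that of compound 1 or that of compound 4. Such groups could help separate the loss of the pyridine nitrogen or the ring from the arrival of the hydroxyl hydrogen.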